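Moving the hydroxyl in compound 2: note on compound 4

The source may hold more compounds than are shown below. What is called first, only, known or untested is meant among the compounds shown, and "the series" means these compounds.

Measured in a functional assay on HeLa cells (Homo sapiens) for cytotoxicity, read by WST assay, with a stated time of 48 h; a higher number here means a weaker inhibitor, a lower number a stronger inhibitor:
Compound 1 `COc1ccc(/C=C/C[C@@H]2C[C@@H]([C@@H](O)c3ccc(OC)c(OC)c3)CO[C@H]2c2ccc(OC)c(OC)c2)cc1OC` gives 30600 nM.
Compound 2 `Oc1cccc(/C=C/C[C@H]2C[C@@H]([C@@H](O)c3ccccc3)CO[C@@H]2c2ccccc2)c1` gives 18600 nM.
Compound 3 `COc1ccc(/C=C/C[C@@H]2C[C@@H]([C@@H](O)c3ccccc3)CO[C@H]2c2ccc(OC)c(OC)c2)cc1OC` gives 16800 nM.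

Compound 2 holds the second highest of the three numbers; compound 3 lies nearest and compound 1 furthest, both gaps within the scatter, so no ranking among the three is claimed. Compound 4 `Oc1ccccc1/C=C/C[C@H]1C[C@@H]([C@@H](O)c2ccccc2)CO[C@@H]1c1ccccc1` differs from compound 2 by 2-hydroxyphenyl in place of 3-hydroxyphenyl on a double-bonded chain carbon bound to a double-bonded chain carbon. Among the measured compounds shown here, the one measured single-point step, a 1.8-fold lower number from compound 1 to compound 3 (0.26 log units; within the scatter), concerns another exchange at another place and stays within the scatter; no measured step tests the exchange of 3-hydroxyphenyl for 2-hydroxyphenyl. The step expected for compound 4 is therefore no change at the digits printed from compound 2 to compound 4 (within the scatter), nothing beyond the scatter. Compound 4 is estimated at 18600 nM, with a range from 7000 nM to 50000 nM.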

Compound 4, half-maximal inhibitory concentration: 21800 nM
Beside the measured number, compound 4's estimate is 1.2-fold (0.07 log units) below it, within the range that was stated.
By their numbers in this assay, from the lowest: compounds 3, 2, 4 and 1 (each within the scatter of the next).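

In this assay, among the compounds shown here, the first measured exchange at this position, on a double-bonded chain carbon bound to a double-bonded chain carbon, gives a 1.2-fold higher number from compound 2 to compound 4 (0.07 log units; within the scatter). Moving the hydroxyl from 3-hydroxyphenyl to 2-hydroxyphenyl therefore leaves the number within the scatter, which the earlier compounds could not show, as their one measured step concerned a different place. Going by these compounds, whether 4-hydroxyphenyl, or an amine or a carboxylic acid in place of the hydroxyl, would take the number beyond the scatter remains open. No evidence is available that bears on this result.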